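A Benzyl-for-tert-butyl Step Carried to a Second Core

The source may hold more compounds than are shown below. What is called first, only, known or untested is meant among the compounds shown, and "the series" means these compounds.

Measured compounds:
compound 1 `CC1=C(C(=O)OC(C)(C)C)C(c2ccoc2)NC(=O)N1` gives 11%
compound 2 `CC1=C(C(=O)OCc2ccccc2)C(c2ccoc2)NC(=O)N1` gives 41%
compound 3 `CC1=C(C(=O)OC(C)(C)C)C(c2cccs2)NC(=S)N1` gives 22%

The three compounds were measured in an assay on membranes from CHO cells for displacement of a labelled ligand from adenosine receptor A1 (Homo sapiens), read by scintillation counting, with a stated time of 60 min, tested at 1 uM; a higher number here means more inhibition at the concentration tested (going by the name of the read-out), a lower number less inhibition. Compound 1 gives 11% and compound 2 gives 41%, the two differing in one place, as benzyl in place of tert-butyl on an oxygen next to a carbonyl group. That change made a step of a number 30 percentage points higher from compound 1 to compound 2 (beyond the scatter).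

Compound 3 gives 22% in this assay. Its core is not that of compound 1, and the difference between the two cores is not broken down here. Compound 4 `CC1=C(C(=O)OCc2ccccc2)C(c2cccs2)NC(=S)N1` has not yet been measured in this assay. Among the compounds with values here, it stands to compound 3 as compound 2 stands to compound 1: the change is benzyl in place of tert-butyl on an oxygen next to a carbonyl group, the same kind of change as the one from compound 1 to compound 2, and in both cases it sits on an oxygen next to a carbonyl group whose other neighbour is the carbonyl carbon.

Because the same change made a step of a number 30 percentage points higher from compound 1 to compound 2 (beyond the scatter), a step of similar direction is expected from compound 3 to compound 4, estimated as a number 26 percentage points higher from compound 3 to compound 4 (beyond the scatter). This expectation rests on a single precedent made on a different core, so its size is uncertain. Compound 4 is expected to give about 48% in this assay, with a range estimated from 25% to 70%.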

Compound 4, a percentage reported as inhibition, at one concentration (the size of the read-out at that concentration, not a potency): 34%
Estimate against measurement, compound 4: 14 percentage points above; the range from low to high includes it.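

On the second core, benzyl in place of tert-butyl on an oxygen next to a carbonyl group again raised the read-out in this assay, with a number 12 percentage points higher from compound 3 to compound 4 (beyond the scatter), so the direction of the change held on both cores shown. The size of the step did not carry over, and the two steps cannot be treated as one shared increment: the same change on two cores in this assay, a number 30 percentage points higher (beyond the scatter) from compound 1 to compound 2 and a number 12 percentage points higher (beyond the scatter) from compound 3 to compound 4, 18 percentage points apart, beyond the scatter of two such steps. This shows only that the direction was the same in two cases; the core of compound 1 and the core of compound 3 differ in more than one place, and these compounds do not tell which of those differences goes with the smaller step, why the size differs, or whether the direction would hold on a further core.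

Going by these compounds, how a methyl group, a longer chain or a benzyl carrying a methoxy group would behave on that same oxygen remains open, as does the outcome of placing an amine there instead of the oxygen. Every number here is also a read-out at a single concentration in one assay, which leaves open how the steps would look as potencies.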